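Permeability of compound 4 after replacing the piperidinyl amide

The source may hold more compounds than are shown below. What is called first, only, known or untested is meant among the compounds shown, and "the series" means these compounds.

Of the compounds shown here, three sharing one core have been measured in an ADME assay on Caco-2 cells (Homo sapiens) for permeability, in the apical to basolateral direction; a higher number here means that the compound crosses the layer faster, a lower number that the compound crosses the layer more slowly. Compound 1 `Cn1cncc1CN1CC(N(CC2CCN(C(=O)C3CCCC3)CC2)S(=O)(=O)c2ccccn2)Cc2cc(C#N)ccc21` gives 0.5 10^-6 cm/s, compound 2 `Cn1cncc1CN1CC(N(CC2CCN(C(=O)C3CC3)CC2)S(=O)(=O)c2ccccn2)Cc2cc(C#N)ccc21` gives 0.5 10^-6 cm/s, and compound 3 `Cn1cncc1CN1CC(N(CC2CCN(C(=O)OC(C)(C)C)CC2)S(=O)(=O)c2ccccn2)Cc2cc(C#N)ccc21` gives 15.5 10^-6 cm/s. Compound 2 thus stands level with compound 1 at the lowest of the three numbers, since no change at the digits printed from compound 1 to compound 2 (within the scatter); compound 3 lies far from both, with a 31-fold higher number from compound 2 to compound 3 (1.49 log units; beyond the scatter) and a 31-fold higher number from compound 1 to compound 3 (1.49 log units; beyond the scatter).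

Compound 4 `Cn1cncc1CN1CC(N(CCn2cccc2)S(=O)(=O)c2ccccn2)Cc2cc(C#N)ccc21` differs from compound 2 as follows: (1H-pyrrol-1-yl)methyl in place of 1-(cyclopropylcarbonyl)piperidin-4-yl on a saturated chain carbon bound to a sulfonamide nitrogen. The measured steps all sit on the same side of the molecule, but each of them only exchanges the group on the carbonyl carbon, and none removes the 1-(cyclopropylcarbonyl)piperidin-4-yl piece altogether. What they do show is that changes in this region range from no effect, as in no change at the digits printed from compound 1 to compound 2 (within the scatter), to a large rise, as in a 31-fold higher number from compound 2 to compound 3 (1.49 log units; beyond the scatter). Among the compounds with values here, for compound 4 an increase in this assay is therefore expected, though smaller and less certain than the one seen for compound 3. For compound 4 the expected step is estimated as a 6.0-fold higher number from compound 2 to compound 4 (0.78 log units; beyond the scatter). Compound 4 is accordingly estimated at 3 10^-6 cm/s, with a range from 0.7 10^-6 cm/s to 12 10^-6 cm/s.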

Compound 4, apparent permeability: 12.4 10^-6 cm/s
Compound 4: middle estimate off by 4.1-fold (0.62 log units), on the low side, and the stated range ends below it.
By their numbers in this assay, from the lowest: compounds 1 and 2 (each within the scatter of the next); then compounds 4 and 3 (each within the scatter of the next).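

In this assay, exchanging the whole 1-(cyclopropylcarbonyl)piperidin-4-yl piece for (1H-pyrrol-1-yl)methyl gives a 25-fold higher number from compound 2 to compound 4 (1.39 log units; beyond the scatter), so this position responds strongly not only to a new group on the carbonyl carbon but also to loss of the piperidine ring and its carbonyl together. Two quite different structures now share the upper level: compound 3 at 15.5 10^-6 cm/s keeps the six-membered ring and has tert-butoxy on the carbonyl carbon, whereas compound 4 at 12.4 10^-6 cm/s has a five-membered aromatic ring, fewer heavy atoms and no carbonyl in this piece, and these two values lie within the scatter of each other. Nothing measured on the compounds themselves is available to explain the rise in compound 4.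

The single exchange alters ring, size and carbonyl at once, so the compounds shown do not separate the contribution of each. They also leave open how this position would respond to a piperidin-4-yl with a free amine, or to a plain butyl chain in place of the (1H-pyrrol-1-yl)methyl group.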